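Series notes: chlorophenyl in place of propyl on the shared core

The compounds below may be only part of what the source reports. "The series", "measured", "known", "first", "only" and "open" are said of these compounds alone.

Measured compounds:
- compound 1 `CCCc1n[nH]c2c(=O)n(NC(=O)c3ccncc3)c(-c3cccc(OC)c3)nc12`, 0.07%
- compound 2 `O=C(Nn1c(-c2cccc([N+](=O)[O-])c2)nc2c(-c3ccc(Cl)cc3)n[nH]c2c1=O)c1cccnc1`, 15.1%

In a functional assay on HT-29 cells (Homo sapiens) for cytotoxicity, read by sulforhodamine B assay, with a stated time of 2 days, tested at 100 uM (a lower number here means less inhibition, a higher number more inhibition at the concentration tested (going by the name of the read-out)), compound 1 gives 0.07%, the lower of the two numbers; compound 2 gives 15.1%, which lies beyond the scatter above it. Compound 3 `COc1cccc(-c2nc3c(-c4ccc(Cl)cc4)n[nH]c3c(=O)n2NC(=O)c2ccncc2)c1` differs from compound 1 by 4-chlorophenyl in place of propyl on an aromatic carbon. Compound 2 also carries a 4-chlorophenyl group, but differs from compound 1 in a second place as well, so its value gives only a loose pointer. For compound 3 a small rise in this assay is expected, the step of a number 6.9 percentage points higher from compound 1 to compound 3 (within the scatter) likely within or just beyond the scatter. Compound 3 is estimated at 7%, with a range from 0% to 22%.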

Compound 3, a percentage reported as inhibition, at one concentration (the size of the read-out at that concentration, not a potency): 46%
Estimate against measurement, compound 3: 39 percentage points below; the measured number lies above the stated range.
By their numbers in this assay, from the lowest: compound 1; then compound 2; then compound 3.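

In this assay, 4-chlorophenyl in place of propyl on this aromatic carbon of the shared core gives a number 45.9 percentage points higher from compound 1 to compound 3 (beyond the scatter) with the rest of compound 1 unchanged. This position alone can therefore shift the read-out strongly, which compound 2 could not show, as it differs from compound 1 in a second place as well.

On these data alone, whether an unsubstituted phenyl, a butyl chain or an amine on this carbon would give a similar number remains open, as does the part played by the chlorine. Nothing available gives a reason for the step.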